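Methoxy in place of ethylsulfanyl on the side chain

The source may report more compounds than this note shows. Statements on the series, on what has been measured and on what is new or still open speak of the compounds shown alone.

compound 1 `CCSCCn1c(N2CCN(C)CC2)nc2ccccc21` — 19 nM
compound 2 `CCOCCn1c(N2CCN(C(c3ccccc3)c3ccccc3)CC2)nc2ccccc21` — > 3000 nM

Among the measured compounds shown here, compound 1, `CCSCCn1c(N2CCN(C)CC2)nc2ccccc21`, gives 19 nM in a functional assay on ileum for inhibition of histamine H1 receptor (Cavia porcellus) (a lower number here means a stronger inhibitor, a higher number a weaker inhibitor), and is the only compound with a number rather than a limit. Compound 2, `CCOCCn1c(N2CCN(C(c3ccccc3)c3ccccc3)CC2)nc2ccccc21`, is reported in this assay only as a limit, > 3000 nM. For the measured compounds named here, that limit, (the limit of > 3000 nM in this assay, at which 1 of the 2 values shown sits), is the only other value available. Going by the values given here, compound 2 differs from compound 1 in more than one place, so no single step between them can be read.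

Compound 3, `COCCn1c(N2CCN(C)CC2)nc2ccccc21`, is not yet measured. It differs from compound 1 in one place: methoxy in place of ethylsulfanyl on a saturated chain carbon, two bonds along the chain from an aromatic nitrogen. Among the compounds with values here, no measured step of this kind exists, so the size of the expected change rests on the structural change alone. A step of modest size is expected in this assay, a 2.1-fold higher number from compound 1 to compound 3 (0.32 log units; beyond the scatter), leaning toward a weaker inhibitor but possibly within the usual scatter. Compound 3 is estimated at 40 nM, with a range from 10 nM to 160 nM.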

Compound 3, half-maximal inhibitory concentration: 13 nM
For compound 3 the middle estimate is 3.1-fold (0.49 log units) above the measured one, within the range that was stated.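

Among the compounds shown here, replacing ethylsulfanyl with methoxy on a saturated chain carbon, two bonds along the chain from an aromatic nitrogen, gives in this assay the first step that can be read at this position, a 1.5-fold lower number from compound 1 to compound 3 (0.16 log units; within the scatter), so for this pair the sulfur of the 2-(ethylsulfanyl)ethyl chain is not needed to keep the value of the 2-methoxyethyl compound within the scatter. The data shown give no cause for this step. Compound 2 remains a limit, > 3000 nM, and it differs from both other compounds in more than one place, so its steps cannot be read.

On these data alone, it remains open whether a 2-hydroxyethyl chain, a chain ending in an amine or a longer alkoxy chain would fit this position equally well. The compounds shown also leave open how the methyl on the piperazine contributes when the 2-methoxyethyl chain is held fixed.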